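Methyl in place of chloro: compound 2 to compound 3

The source may report more compounds than this note shows. Statements on the series, on what has been measured and on what is new or still open speak of the compounds shown alone.

Going by the values given here, in an in vivo ADME assay on the whole organism (strain Sprague-Dawley) for pharmacokinetics, with Rattus norvegicus as the target, at a dose of 2 mg/kg by the oral route (on this read-out higher numbers stand for higher oral bioavailability and lower numbers for lower oral bioavailability), only two compounds have numbers so far. Compound 1 `CC(C)C1(c2ccc(-c3ccc4ccccc4c3)[nH]c2=O)OC(=O)NC1=O` gives 100%, and compound 2 `CC(C)C1(c2cc(Cl)c(-c3ccc4ccccc4c3)[nH]c2=O)OC(=O)NC1=O` gives 86%. Among the compounds with values here, compound 2 therefore holds the lower of the two numbers, and compound 1 is its only neighbour.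

Compound 3 `Cc1cc(C2(C(C)C)OC(=O)NC2=O)c(=O)[nH]c1-c1ccc2ccccc2c1` differs from compound 2 at one place: methyl in place of chloro on an aromatic carbon. Within the data shown here, no measured step exchanges chloro for methyl, so the evidence is indirect. Among the measured compounds shown here, the one measured step, chloro in place of hydrogen on an aromatic carbon, is a number 14 percentage points lower from compound 1 to compound 2 (beyond the scatter). It is a modest step, and it is the only measure of how much a change at this carbon can move the number in this assay.

With a single step to go on, no direction can be argued from the data. The expectation is no step beyond the scatter, though a step of the size seen for chloro remains possible either way. The estimated step is a number 1 percentage points lower from compound 2 to compound 3 (within the scatter). Compound 3 is expected at 85%, with an estimated range of 66% to 100%.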

Compound 3, oral bioavailability: 100%
Estimate against measurement, compound 3: 15 percentage points below; measured number inside the range.
By their numbers in this assay, from the lowest: compound 2; then compounds 1 and 3 (each within the scatter of the next).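

Methyl in place of chloro on this aromatic carbon gives a number 14 percentage points higher from compound 2 to compound 3 (beyond the scatter) in this assay, while methyl in place of hydrogen gives no change at the digits printed from compound 1 to compound 3 (within the scatter). The earlier compounds shown here alone left open whether any replacement of hydrogen at this carbon would go with a lower number; here, of two groups with the same count of 1 heavy atom, only chloro is set apart from hydrogen by a step beyond the scatter, so the step depends on which group enters and not just on the carbon being substituted. Nothing available explains why chloro and methyl part here.

Besides hydrogen, the compounds shown cover only these two groups of 1 heavy atom at this carbon, so it remains open whether a larger group, such as an ethyl or a methoxy group, would stay level with hydrogen and methyl or fall away as chloro does. On these data alone, an amine or a carboxylic acid at this carbon is equally open, as is whether these steps carry over when the large group on the neighbouring part of the shared core is changed.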